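From Z to E at one double bond

The source may report more compounds than this note shows. Statements on the series, on what has been measured and on what is new or still open speak of the compounds shown alone.

Values measured in a functional assay on MCF7 cells (Homo sapiens) for cytotoxicity, read by MTT assay, with a stated time of 48 h (on this read-out lower numbers stand for stronger inhibition and higher numbers for weaker inhibition), are as follows
- compound 1 `CCOC(=O)C1=C(C)NC(=S)NC1c1cccc(OCCCCOc2cccc(C3NC(=S)NC(C)=C3C(=O)OCC)c2)c1` gives 186 ug/mL
- compound 2 `CCOC(=O)C1=C(C)NC(=S)NC1c1cccc(OCCCCCOc2cccc(C3NC(=S)NC(C)=C3C(=O)OCC)c2)c1` gives 178 ug/mL
- compound 3 `CCOC(=O)C1=C(C)NC(=S)NC1c1cccc(OC/C=C\COc2cccc(C3NC(=S)NC(C)=C3C(=O)OCC)c2)c1` gives 49 ug/mL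

Compound 3 has the lowest number of the three, which in this assay means the strongest inhibition, and it lies beyond the usual scatter from both others. The unmeasured compound 4 `CCOC(=O)C1=C(C)NC(=S)NC1c1cccc(OC/C=C/COc2cccc(C3NC(=S)NC(C)=C3C(=O)OCC)c2)c1` differs from compound 3 by the two compounds have the same atoms and bonds; at least one stereo element is drawn with a configuration in one of them and without one in the other: 1 of 3 stereo elements differ; a double bond is drawn Z in compound 3 and E in compound 4 and nothing else: the two have the same atoms and bonds, but a double bond is drawn Z in compound 3 and E in compound 4. Among the measured compounds shown here, no measured pair here shows what such a switch does, so any forecast is loose. A moderate rise toward the higher numbers of compound 1 and compound 2 is expected, and it may not clear the scatter. The expected move is a 1.6-fold higher number from compound 3 to compound 4 (0.21 log units; within the scatter) in size. For compound 4 the estimated value is 80 ug/mL (30 ug/mL to 190 ug/mL).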

Compound 4, half-maximal inhibitory concentration: 175 ug/mL
Compound 4: middle estimate off by 2.2-fold (0.34 log units), on the low side; the measured number falls inside the stated range.
By their numbers in this assay, from the lowest: compound 3; then compounds 4, 2 and 1 (each within the scatter of the next).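

The chain linking the two halves keeps all its atoms and bonds, and only its double bond goes from Z to E, yet in this assay this gives a 3.6-fold higher number from compound 3 to compound 4 (0.55 log units; beyond the scatter). Among the compounds shown here, this is the first pair differing in one place, and it shows that the geometry at this double bond alone can move the number beyond the scatter. The reading carries one caution about how the structures are drawn: the fact that one of compounds 3 and 4 is drawn with a defined configuration and the other without, at the place where they differ

On these data alone, whether a longer chain holding a Z double bond, or a triple bond in its place, would give a number like that of compound 3 stays open.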